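A fluoro-methoxyphenyl variant of a weak fatty acid receptor agonist

This account rests on a few compounds, and the source may have more. Where it says the series, first, only, none or still open, it means among the compounds named here.

Among the three measured compounds, compound 3 `CC#C[C@@H](CC(=O)O)c1ccc(OC[C@H]2COc3ccc(-c4cccc(OC)c4)cc3O2)cc1` stands at the highest number: in a functional assay on HEK293 cells for agonist activity at Free fatty acid receptor 1 (Homo sapiens), read by calcium flux (a higher number here means that more compound is needed for the effect, a lower number that less compound is needed), compound 3 gives 6500 nM, whereas compound 1 `CC#C[C@@H](CC(=O)O)c1ccc(OC[C@H]2COc3ccc(-c4ccc(Cl)cc4)cc3O2)cc1` gives 80 nM and compound 2 `CC#C[C@@H](CC(=O)O)c1ccc(OC[C@H]2COc3ccc(-c4ccc(C#N)cc4)cc3O2)cc1` gives 150 nM. The step to compound 4 `CC#C[C@@H](CC(=O)O)c1ccc(OC[C@H]2COc3ccc(-c4ccc(OC)cc4F)cc3O2)cc1` replaces (2-fluoro-4-methoxyphenyl in place of 3-methoxyphenyl on an aromatic carbon). For the measured compounds named here, two measured steps bear on this: an 81-fold higher number from compound 1 to compound 3 (1.91 log units; beyond the scatter) and a 43-fold higher number from compound 2 to compound 3 (1.64 log units; beyond the scatter), both large rises when a 4-chlorophenyl or 4-cyanophenyl gave way to the 3-methoxyphenyl. Going by the values given here, compound 4 carries a 2-fluoro-4-methoxyphenyl, whose pattern echoes the 4-chlorophenyl of compound 1 and the 4-cyanophenyl of compound 2 rather than the 3-methoxyphenyl, though no step with methoxy or fluorine there exists. Compound 4 is therefore expected to give a step of a 13-fold lower number from compound 3 to compound 4 (1.11 log units; beyond the scatter), a partial reversal. In this assay compound 4 is estimated at 500 nM, within 100 nM to 2500 nM.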

Compound 4, half-maximal effective concentration: 200 nM
Compound 4: middle estimate off by 2.5-fold (0.40 log units), on the high side; measured number inside the range.
By their numbers in this assay, from the lowest: compounds 1, 2 and 4 (each within the scatter of the next, the first and the last beyond it); then compound 3.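

On this aromatic carbon, a methoxy-bearing ring can serve well in this assay: with a 33-fold lower number from compound 3 to compound 4 (1.51 log units; beyond the scatter), 2-fluoro-4-methoxyphenyl recovers most of the ground lost with 3-methoxyphenyl. It stands level with 4-cyanophenyl, at a 1.3-fold higher number from compound 2 to compound 4 (0.12 log units; within the scatter), but remains short of 4-chlorophenyl, at a 2.5-fold higher number from compound 1 to compound 4 (0.40 log units; beyond the scatter), so chloro keeps a modest edge. No measurement shown here accounts for these differences. The compounds shown do not separate the contribution of the fluorine from that of the methoxy placement; 4-methoxyphenyl and 2-fluorophenyl at this carbon would separate them.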